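The source may report more compounds than this note shows. Statements on the series, on what has been measured and on what is new or still open speak of the compounds shown alone.

Measured so far:
- Compound 1 `CC(C)NC(=N)NC(=N)Nc1ccc(F)c(F)c1`: > 50000 nM (a limit)
- Compound 2 `CC(C)NC(=N)NC(=N)Nc1ccc(F)cc1`: > 50000 nM (a limit)
- Compound 3 `CCN(CC)C(=N)NC(=N)Nc1ccc(C(F)(F)F)cc1`: 4300 nM

In a functional assay on HCT-116 cells (Homo sapiens) for antiproliferative activity, read by MTT assay, with a stated time of 72 h (on this read-out higher numbers stand for weaker inhibition and lower numbers for stronger inhibition), compound 1 has no number, only the limit > 50000 nM. Compound 2 also stands only at a limit. Compound 3 alone gives a number, so a reading inside the range of this assay is possible among these compounds, although compound 3 differs from compound 1 in more than one place.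

The next compound is compound 4 `N=C(NC(=N)NC1CCCC1)Nc1ccc(F)c(F)c1`. The change from compound 1 is cyclopentyl in place of isopropyl on an amine nitrogen.

Among the measured compounds shown here, only one measured step lies close to this change: a step that the two limits leave unreadable from compound 1 to compound 2. It gives no size to carry over, and it concerns an aromatic carbon rather than the amine nitrogen. The remaining guide is the limit of > 50000 nM in this assay, at which 2 of the 3 values shown sit. A large move is therefore not expected, and compound 4 may well stay at the limit. If a number appears, a modest step towards stronger inhibition is expected, with compound 3 at 4300 nM marking how far the series has reached.

The expected step is an at least 1.4-fold lower number from compound 1 to compound 4 (0.15 log units; that floor lies within the scatter). For compound 4 the estimated value is 35000 nM, with an expected range of 12000 nM to 50000 nM.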

Compound 4, half-maximal inhibitory concentration: 16800 nM
The estimate for compound 4 lay 2.1-fold (0.32 log units) above the measured number; the measured number falls inside the stated range.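

In this assay, among the compounds shown here, cyclopentylamino in place of isopropylamino on the core of compound 1 gives the first readable step at this amine nitrogen, an at least 2.9-fold lower number from compound 1 to compound 4 (0.47 log units; beyond the scatter). On these data alone, the value of compound 1, > 50000 nM, is a limit, so the size of this step is only a floor and the full size stays unknown. With the rest of compound 1 held fixed, this nitrogen is a place where the read-out responds to the group it carries, which the unreadable step between compound 1 and compound 2 could not show, although the limit remains common in the series: the limit of > 50000 nM in this assay, at which 2 of the 4 values shown sit.

The change adds carbon and a ring together, so the compounds shown do not tell which of the two goes with the step; an open-chain pentyl group on the same nitrogen would separate them. Also open, as far as these compounds go, is whether the step extends to a larger ring such as cyclohexyl, and whether it holds on the core of compound 2, which carries one fluoro group fewer.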